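A Trimethoxyphenyl Swap Repeated on a Second Core

The source may report more compounds than this note shows. Statements on the series, on what has been measured and on what is new or still open speak of the compounds shown alone.

Compound 3 `COc1cc(/C=C/C(=O)/C=C/c2ccccc2)ccc1OCc1cn(CCOc2cc(=O)oc3ccccc23)nn1` and compound 1 `COc1cc(/C=C/C(=O)/C=C/c2cc(OC)c(OC)c(OC)c2)ccc1OCc1cn(CCOc2cc(=O)oc3ccccc23)nn1` share a core and differ only where (3,4,5-trimethoxyphenyl in place of phenyl on a double-bonded chain carbon bound to a double-bonded chain carbon). In a functional assay on COLO 205 cells (Homo sapiens) for inhibition, read by sulforhodamine B assay, with a stated time of 48 h, tested at 50 uM (a lower number here means less inhibition of growth, a higher number more inhibition of growth at the concentration tested), compound 3 gives 54%, while compound 1 gives 86%, which is a number 32 percentage points higher from compound 3 to compound 1 (beyond the scatter). Compound 2 `COc1cc(/C=C/C(=O)/C=C/c2ccccc2)ccc1OCc1cn(CCCCCOc2cc(=O)oc3ccccc23)nn1` rests on a different core; the difference between the two cores is not broken down here. In this assay compound 2 gives 22%, the lowest of the three numbers. Compound 4 `COc1cc(/C=C/C(=O)/C=C/c2cc(OC)c(OC)c(OC)c2)ccc1OCc1cn(CCCCCOc2cc(=O)oc3ccccc23)nn1` has not yet been measured; it differs from compound 2 where (3,4,5-trimethoxyphenyl in place of phenyl on a double-bonded chain carbon bound to a double-bonded chain carbon), the same change as from compound 3 to compound 1. Because that earlier step was a number 32 percentage points higher from compound 3 to compound 1 (beyond the scatter), a step of similar size is expected here, a number 32 percentage points higher from compound 2 to compound 4 (beyond the scatter). Compound 4 is therefore estimated at 54% in this assay, most likely between 35% and 75%.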

Compound 4, percent growth inhibition at one concentration: 51%
Compound 4: the middle estimate sits 3 percentage points above what was measured; low and high end bracket the measured number.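

In this assay, putting 3,4,5-trimethoxyphenyl in place of phenyl gives a number 29 percentage points higher from compound 2 to compound 4 (beyond the scatter). The change therefore carries over from one core to the other with a step of much the same size: the same change on two cores in this assay, a number 32 percentage points higher (beyond the scatter) from compound 3 to compound 1 and a number 29 percentage points higher (beyond the scatter) from compound 2 to compound 4, 3 percentage points apart, within the scatter of two such steps. This is a single pair of cores tested on one cell line at one concentration, so it does not show that the step would hold on other cores, nor does it explain why the group has this effect.

The compounds shown carry only phenyl or 3,4,5-trimethoxyphenyl at this place, so it stays open how a ring bearing a single methoxy group or an amine would behave. As far as these compounds go, it also stays open whether the step would persist with a longer chain on the core.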